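This account rests on a few compounds, and the source may have more. Where it says the series, first, only, none or still open, it means among the compounds named here.

Compound 1 `COc1ccc(F)cc1CNCCCNc1ccnc2cc(Oc3ccc(Cl)cc3)ccc12`: 4500 nM
Compound 2 `COc1ccc(F)cc1CNCCCNc1ccnc2cc(-c3cccc4ccccc34)ccc12`: 16000 nM
Compound 3 `COc1cccc(CNCCCNc2ccnc3cc(-c4cccc5ccccc45)ccc23)c1O`: 2520 nM

In an ADME assay on HepG2 cells (Homo sapiens) for cytotoxicity, read by luminescence, CellTiter-Glo and ATP content, with a stated time of 72 h (on this read-out higher numbers stand for an effect only at larger amounts of compound and lower numbers for an effect already at smaller amounts), the number for compound 3 sits lowest, though its gap to compound 1 lies within the scatter. Compound 4 `COc1cccc(CNCCCNc2ccnc3cc(Oc4ccc(Cl)cc4)ccc23)c1O` is not yet measured. The change that leads from compound 3 to compound 4 is 4-chlorophenoxy in place of naphthalen-1-yl on an aromatic carbon; the same change, (4-chlorophenoxy in place of naphthalen-1-yl on an aromatic carbon), has been made once before and gave a 3.6-fold lower number from compound 2 to compound 1 (0.55 log units; beyond the scatter). The two cores on which it is made differ by 2-hydroxy-3-methoxyphenyl in place of 5-fluoro-2-methoxyphenyl on a saturated chain carbon bound to an amine nitrogen, a change that on its own gave a 6.3-fold lower number from compound 2 to compound 3 (0.80 log units; beyond the scatter). Because the earlier step of a 3.6-fold lower number from compound 2 to compound 1 (0.55 log units; beyond the scatter) was modest, a step of similar size is expected from compound 3 to compound 4, namely a 3.4-fold lower number from compound 3 to compound 4 (0.53 log units; beyond the scatter). Compound 4 is therefore estimated at 750 nM, with the range 300 nM to 2000 nM.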

Compound 4, half-maximal effective concentration: 5700 nM
The estimate for compound 4 lay 7.6-fold (0.88 log units) below the measured number, outside the stated range (above it).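

In this assay, 4-chlorophenoxy in place of naphthalen-1-yl does not carry from one core to the other, since on the core of compound 3 it gives a 2.3-fold higher number from compound 3 to compound 4 (0.35 log units; beyond the scatter), against an earlier step in the opposite direction: the same change on two cores in this assay, a 3.6-fold lower number (0.55 log units; beyond the scatter) from compound 2 to compound 1 and a 2.3-fold higher number (0.35 log units; beyond the scatter) from compound 3 to compound 4, 8.0-fold (0.91 log units) apart, beyond the scatter of two such steps

Likewise, 2-hydroxy-3-methoxyphenyl in place of 5-fluoro-2-methoxyphenyl gives a 1.3-fold higher number from compound 1 to compound 4 (0.10 log units; within the scatter) once 4-chlorophenoxy is present, so its effect also depends on the core: the same change on two cores in this assay, a 6.3-fold lower number (0.80 log units; beyond the scatter) from compound 2 to compound 3 and a 1.3-fold higher number (0.10 log units; within the scatter) from compound 1 to compound 4, 8.0-fold (0.91 log units) apart, beyond the scatter of two such steps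

Across these four compounds the two changes do not simply add up, but the numbers do not show why, nor how either change would behave on any other core.

Still open, going by these compounds, is whether the same reversal appears with a plain phenoxy or a morpholine on that aromatic carbon, or with a longer saturated chain.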